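Shortening the chain in the shared core series

The compounds below may be only part of what the source reports. "The series", "measured", "known", "first", "only" and "open" are said of these compounds alone.

Compound 1 `CCCCCCn1c(N2CCN(C)CC2)nc2ccccc21` gives 26 nM in a functional assay on ileum for inhibition of histamine H1 receptor (Cavia porcellus) (on this read-out higher numbers stand for weaker inhibition and lower numbers for stronger inhibition), the highest of the three numbers gathered so far. Compound 2 `CCCCN1CCN(c2nc3ccccc3n2CCOCC)CC1` gives 15 nM, and its gap from compound 1 lies within the scatter, so no order between them is claimed. Compound 3 `CCCCCN1CCCN(c2nc3ccccc3n2CCOCC)CC1` gives 7.4 nM, a gap from compound 1 that lies beyond the scatter. Compound 4 `CCCn1c(N2CCN(C)CC2)nc2ccccc21` differs from compound 1 in one place: hydrogen in place of propyl on a saturated chain carbon, three bonds along the chain from an aromatic nitrogen. Within the data shown here, no measured pair shows this change, so its size is not known from the data. Some rise in the number is expected, with the step from compound 1 to compound 4 estimated at a 2.3-fold higher number from compound 1 to compound 4 (0.36 log units; beyond the scatter). Compound 4 is expected to give 60 nM in this assay, with a range of 20 nM to 200 nM.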

Compound 4, half-maximal inhibitory concentration: 380 nM
Beside the measured number, compound 4's estimate is 6.3-fold (0.80 log units) below it; measured number above the stated range.
By their numbers in this assay, from the lowest: compound 3; then compounds 2 and 1 (each within the scatter of the next); then compound 4.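

In this assay, hydrogen in place of propyl on a saturated chain carbon, three bonds along the chain from an aromatic nitrogen, gives a large step: a 15-fold higher number from compound 1 to compound 4 (1.16 log units; beyond the scatter). The outer part of the hexyl chain therefore counts at this position, which compounds 2 and 3 could not show, as neither differs from compound 1 in one place only. Nothing available explains the size of this step.

Open, from the compounds shown here alone, are the intermediate butyl and pentyl chains, so it remains unknown whether the number rises gradually or at one chain length. Also open, going by these compounds, are a longer chain such as octyl and a hexyl chain ending in an amine.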